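A few compounds are considered here, and "the series" means these few. Any claim that something is new, unique, unknown or untested is made for them only; others in the source may bear on it.

Measured so far:
compound 1 `Cn1c(=O)c(S(=O)(=O)c2ccc(F)cc2F)cc2cnc(Nc3cccc4[nH]ccc34)nc21`: 750 nM
compound 2 `Cn1c(=O)c(S(=O)(=O)c2ccc(F)cc2)cc2cnc(Nc3cccc4[nH]ccc34)nc21`: 750 nM
compound 3 `Cc1ccc(S(=O)(=O)c2cc3cnc(Nc4cccc5cccnc45)nc3n(C)c2=O)cc1`: 10000 nM

In a functional assay on DU-145 cells (Homo sapiens) for inhibition, read by trypan blue exclusion, with a stated time of 72 h (a higher number here means a weaker inhibitor, a lower number a stronger inhibitor), compound 1 stands level with compound 2, and the two of them give the lowest numbers of the three. Among the compounds with values here, compound 3 gives a much higher number, but it differs from compound 1 in two places at once, so its value shows only that both changes together weaken inhibition, not which one is responsible. Within the data shown here, the one single step that has been measured, no change at the digits printed from compound 1 to compound 2 (within the scatter), touches the sulfonyl-bearing ring and not the bicyclic amine, so it says little about what happens on that side.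

Compound 4 `Cn1c(=O)c(S(=O)(=O)c2ccc(F)cc2F)cc2cnc(Nc3ccc4[nH]ncc4c3)nc21` is not yet measured. It differs from compound 1 in one place: 1H-indazol-5-yl in place of 1H-indol-4-yl on a nitrogen on an aromatic ring. Among the measured compounds shown here, no measured step concerns this part of the molecule, so the expectation rests on the general observation that the bicyclic amine can matter, as compound 3 hints. A modest weakening is expected, a 2.0-fold higher number from compound 1 to compound 4 (0.30 log units; within the scatter), with wide uncertainty. Compound 4 is therefore estimated at 1500 nM, within a range of 400 nM to 6000 nM.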

Compound 4, half-maximal inhibitory concentration: 30000 nM
The estimate for compound 4 lay 20-fold (1.30 log units) below the measured number; measured number outside the range, above it.
By their numbers in this assay, from the lowest: compounds 1 and 2 (each within the scatter of the next); then compound 3; then compound 4.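

In this assay, putting 1H-indazol-5-yl in place of 1H-indol-4-yl on the nitrogen gives a 40-fold higher number from compound 1 to compound 4 (1.60 log units; beyond the scatter), the first single change measured at this position, and it shows that one bicyclic group cannot simply be swapped for a similar one here. The contrast with the fluoro-to-hydrogen change on the sulfonyl-bearing ring is sharp, since that step gives no change at the digits printed from compound 1 to compound 2 (within the scatter). No measurement at hand explains the large loss of inhibition.

This swap alters two things at once, the ring atoms and the point of attachment, so the compounds shown cannot separate their contributions. Going by these compounds, a 1H-indol-5-yl or 1H-indazol-4-yl group on the same nitrogen would change only one of these, and how either would compare with compound 1 remains open.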